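Bromophenyl ether analogues in the A549 antiproliferation series

This account rests on a few compounds, and the source may have more. Where it says the series, first, only, none or still open, it means among the compounds named here.

Measured compounds:
compound 1 `COc1ccc(OCCCON2C(N)=NC(N)=NC23CCOCC3)cc1` — 660 nM
compound 2 `NC1=NC2(CCOCC2)N(OCCCOc2ccccc2Br)C(N)=N1` — 160 nM
compound 3 `NC1=NC2(CCOCC2)N(OCCCOc2cccc(Br)c2)C(N)=N1` — 160 nM

All three share one core and differ only in the aryl ether at the end of the chain. In a functional assay on A549 cells (Homo sapiens) for antiproliferative activity, read by MTT assay, with a stated time of 72 h (a lower number here means a stronger inhibitor, a higher number a weaker inhibitor), compound 1 gives 660 nM, the highest of the three numbers; compound 2 gives 160 nM and compound 3 gives 160 nM. The step of a 4.1-fold lower number from compound 1 to compound 2 (0.62 log units; beyond the scatter) and the step of a 4.1-fold lower number from compound 1 to compound 3 (0.62 log units; beyond the scatter) are of the same size, both beyond the scatter, whereas no change at the digits printed from compound 2 to compound 3 (within the scatter) shows that exchanging 2-bromophenyl for 3-bromophenyl made no difference that can be read.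

Compound 4 `NC1=NC2(CCOCC2)N(OCCCOc2ccc(Br)cc2)C(N)=N1` is the remaining bromophenyl isomer. Relative to compound 1 it carries bromo in place of methoxy on an aromatic carbon, the same 4-methoxyphenyl to bromophenyl exchange as in the two measured steps. Both of those steps gave a lower number of modest size, and the two bromine placements did not differ from each other, so a step of similar size and direction is expected here. Compound 4 is therefore estimated at 170 nM, with a range of 80 nM to 400 nM, which would correspond to a step of a 3.9-fold lower number from compound 1 to compound 4 (0.59 log units; beyond the scatter). Among the measured compounds shown here, no measured pair shows bromine para to a large group, so the range is kept wide.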

Compound 4, half-maximal inhibitory concentration: 280 nM
Beside the measured number, compound 4's estimate is 1.6-fold (0.22 log units) below it, and the stated range covers the measured number.
By their numbers in this assay, from the lowest: compounds 2, 3 and 4 (each within the scatter of the next); then compound 1.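

In this assay, bromo in place of methoxy on an aromatic carbon, para to a large group, gives a 2.4-fold lower number from compound 1 to compound 4 (0.37 log units; beyond the scatter), so all three bromophenyl ethers now stand on the same side of compound 1, with none going against it. The two steps that move the bromine to this place, a 1.8-fold higher number from compound 3 to compound 4 (0.24 log units; within the scatter) and a 1.8-fold higher number from compound 2 to compound 4 (0.24 log units; within the scatter), add a third placement and still show no difference that can be read among the bromine isomers, so compound 2, compound 3 and compound 4 form one group on this measure. No independent evidence bears on this result, and the exchange of methoxy for bromo remains an observation without an explanation.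

Going by these compounds, whether the lower number is specific to bromo or would also appear with chloro, trifluoromethyl or a plain phenyl stays open. Also open, on these data alone, is how a longer chain between the shared core and the aryl ether, or an amine on the aromatic ring, would read in this assay.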